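Swapping the cyclobutyl for a hydroxymethyl-bearing chain

A few compounds are considered here, and "the series" means these few. Any claim that something is new, unique, unknown or untested is made for them only; others in the source may bear on it.

Measured compounds:
compound 1 `O=C(NC1(C(=O)NO)CCC1)c1ccc(C#Cc2ccccc2)cc1`, > 3
compound 2 `O=C(NC1(C(=O)NO)CCNCC1)c1ccc(C#Cc2ccccc2)cc1`, 3

In a physicochemical assay for lipophilicity (a higher number here means a more lipophilic compound, a lower number a more polar compound), compound 1 reaches only a limit of the assay, > 3, with no number behind it (the limit of > 3 in this assay, at which 1 of the 2 values shown sits). Compound 2 gives 3 in this assay. Compound 3 `O=C(N[C@H](CO)C(=O)NO)c1ccc(C#Cc2ccccc2)cc1` has not yet been measured. It differs from compound 1 in one place: a group of 7 heavy atoms (3 carbon, 1 nitrogen, 3 oxygen; no ring) in place of a group of 8 heavy atoms (5 carbon, 1 nitrogen, 2 oxygen; one four-membered non-aromatic ring of carbon only), on an amide-type nitrogen. The account expects a decrease beyond the scatter in this assay, a step of a number at least 1.00 log units lower from compound 1 to compound 3 (beyond the scatter). Compound 3 is therefore estimated at 2, within a range from 1.4 to 2.6.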

Compound 3, distribution coefficient: 2
Beside the measured number, compound 3's estimate shows no gap at the digits printed; the measured number falls inside the stated range.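

For the compounds shown here, on the amide-type nitrogen, replacing the 1-(hydroxycarbamoyl)cyclobutyl group with the open chain of compound 3 gives a step of a number at least 1.00 log units lower from compound 1 to compound 3 (beyond the scatter) in this assay, the only step that can be read at this position. That step is a minimum, because compound 1 stands at a limit of the assay: the limit of > 3 in this assay, at which 1 of the 3 values shown sits.

The compounds shown do not separate the loss of the ring from the gain of the hydroxyl. From the compounds shown here alone, how an amine, a carboxylic acid or a longer chain on this nitrogen would read in this assay remains open.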